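Oral exposure notes: thiophene in place of isoxazole

This account rests on a few compounds, and the source may have more. Where it says the series, first, only, none or still open, it means among the compounds named here.

Measured so far in an ADME assay on the whole organism (Rattus norvegicus) for pharmacokinetics, at a dose of 1 mg/kg by the oral route; a higher number here means that a larger share of the oral dose reaches the circulation, a lower number that a smaller share of the oral dose reaches the circulation:
Compound 1 `COc1ccccc1C1C(C(=O)C(C)(C)C)=C(O)C(=O)N1c1ccc(-c2ccon2)cc1`: 77.9%
Compound 2 `COc1ccc(C(=O)C2=C(O)C(=O)N(c3ccc(-c4ccon4)cc3)C2c2ccccc2OCCO)cc1`: 9%
Compound 3 `CC(C)(C)C(=O)C1=C(O)C(=O)N(c2ccc(-c3ccon3)cc2)C1c1ccccc1OCCO`: 49.9%

Compound 3 stands second highest of the three numbers; compound 1 lies above it, a number 28 percentage points lower from compound 1 to compound 3 (beyond the scatter), and compound 2 lies below it, a number 40.9 percentage points higher from compound 2 to compound 3 (beyond the scatter). Compound 4 `CC(C)(C)C(=O)C1=C(O)C(=O)N(c2ccc(-c3cccs3)cc2)C1c1ccccc1OCCO` differs from compound 3 by thiophen-2-yl in place of 1,2-oxazol-3-yl on an aromatic carbon. Neither measured step touches this place: the step from compound 1 to compound 3 alters the chain on the ring oxygen, the step from compound 2 to compound 3 alters the group on the carbonyl carbon, and both were beyond the scatter. Going by the values given here, no step that exchanges one five-membered aromatic ring for another has been measured, so nothing sets the size or direction of this change. In this assay the change is therefore expected to give a step that stays within the scatter, a number 4.9 percentage points lower from compound 3 to compound 4 (within the scatter), with wide uncertainty around it. Compound 4 is estimated at 45%, with a range from 20% to 70%.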

Compound 4, oral bioavailability: 65.2%
Estimate against measurement, compound 4: 20.2 percentage points below, and the stated range covers the measured number.
By their numbers in this assay, from the lowest: compound 2; then compound 3; then compound 4; then compound 1.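

In this assay, the five-membered aromatic ring on the six-membered aromatic ring of carbon only is a place that bears on the read-out: thiophen-2-yl in place of 1,2-oxazol-3-yl gives a number 15.3 percentage points higher from compound 3 to compound 4 (beyond the scatter). The series thus has a third place of change, besides the chain on the ring oxygen and the group on the carbonyl carbon, and this exchange, with one hetero atom and one hydrogen-bond acceptor fewer in the entering ring, moves the number upward. Nothing measured here accounts for this step.

Going by these compounds, how a furan-2-yl or a pyridin-3-yl group would read at this place remains open. Also open, on these data alone, is whether the thiophen-2-yl step carries over to the frameworks of compound 1 and compound 2.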